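Sulfonylpiperidine series: cytotoxicity limits and a ring swap

A few compounds are considered here, and "the series" means these few. Any claim that something is new, unique, unknown or untested is made for them only; others in the source may bear on it.

Three compounds of the series have been run in an ADME assay on HCT-116 cells (Homo sapiens) for cytotoxicity, read by CellTiter-Glo, with a stated time of 72 h; a higher number here means a weaker inhibitor, a lower number a stronger inhibitor. Compound 1 `CC1CCN(C2CCN(S(=O)(=O)c3cccc(-c4ccccc4C(F)(F)F)c3)CC2)CC1` reaches only the limit of the run, > 5000 nM. Compound 2 `Cc1cc(C)c(S(=O)(=O)N2CCC(C3OCC(C)CO3)CC2)c(C)c1` likewise gives a limit, > 5000 nM. Compound 3 `Cc1ccc(-c2ccccc2S(=O)(=O)N2CCC(N3CCC(C)CC3)CC2)cc1` also returns a limit, > 5000 nM. So compound 2 stands where every measured compound stands, at the limit of > 5000 nM in this assay, at which 3 of the 3 values shown sit, with no number that would rank it against the other two.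

Compound 4 `Cc1cc(C)c(S(=O)(=O)N2CCC(N3CCC(C)CC3)CC2)c(C)c1` has not yet been measured. It differs from compound 2 in one place (a group of 7 heavy atoms (6 carbon, 1 nitrogen; one six-membered non-aromatic ring with 1 hetero atom) in place of a group of 7 heavy atoms (5 carbon, 2 oxygen; one six-membered non-aromatic ring with 2 hetero atoms), on a saturated ring carbon). The group that enters, 4-methylpiperidin-1-yl, is the group that compound 1 and compound 3 carry on the same kind of saturated ring carbon.

Within the data shown here, no step between measured compounds is available, so the size of the change from compound 2 to compound 4 in this assay cannot be read from the data. Among the measured compounds shown here, compound 4 is nevertheless expected to sit at the limit too, because every measured value so far sits at the limit of > 5000 nM in this assay, at which 3 of the 3 values shown sit. The step that the limit leaves unreadable from compound 2 to compound 4 is therefore expected to be none beyond the usual scatter. The estimate for compound 4 in this assay is 10000 nM, with a range from 4000 nM to 30000 nM.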

Compound 4, half-maximal inhibitory concentration: > 5000 nM
Compound 4: only a limit was reported; the forecaster's own chance of this, stated with the estimate: 80%; the middle value is on the limit's open side.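

In this assay compound 4 gives > 5000 nM, which is a limit and not a number. Among these compounds, compound 2 also stands at a limit, so no step from compound 2 to compound 4 can be read. The compounds shown leave open whether any member of the series gives a readable value in this assay, and how 4-methylpiperidin-1-yl ranks against the group it replaces, with every value at the same point: the limit of > 5000 nM in this assay, at which 4 of the 4 values shown sit.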